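Nitro in Place of Bromo: an Expected Small Step

The source may report more compounds than this note shows. Statements on the series, on what has been measured and on what is new or still open speak of the compounds shown alone.

Compound 1, `CN(C(=O)c1ccc(F)cc1)c1ccc2[nH]c(-c3n[nH]c4ccccc34)cc2n1`, gives 1210 nM in a functional assay on HL-60 cells (Homo sapiens) for antiproliferative activity, read by MTT assay, with a stated time of 72 h; a lower number here means a stronger inhibitor, a higher number a weaker inhibitor.
Compound 2, `CN(C(=O)c1ccc(Br)cc1)c1ccc2[nH]c(-c3n[nH]c4ccccc34)cc2n1`, gives 1080 nM in this assay.

Of the compounds shown here, two have been measured, and they differ only in the halogen on the 4-substituted phenyl ring. For the measured compounds named here, the step of a 1.1-fold lower number from compound 1 to compound 2 (0.05 log units; within the scatter) is the only measured step, and it lies within the scatter. Compound 2 therefore stands with the lower of the two numbers, but its nearest neighbour, compound 1, is so close that no order between them can be read.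

Compound 3, `CN(C(=O)c1ccc([N+](=O)[O-])cc1)c1ccc2[nH]c(-c3n[nH]c4ccccc34)cc2n1`, continues from compound 2 with the change (nitro in place of bromo on an aromatic carbon). Going by the values given here, the only step that bears on this position, the step from fluoro to bromo, was within the scatter, and nothing measured tells how a nitro group at this place behaves. Given the flat step from compound 1 to compound 2, compound 3 is expected to show a step of a 1.1-fold lower number from compound 2 to compound 3 (0.03 log units; within the scatter) in this assay, that is, no change beyond the scatter. The estimate for compound 3 in this assay is 1000 nM, with a range from 350 nM to 3000 nM.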

Compound 3, half-maximal inhibitory concentration: 6800 nM
The estimate for compound 3 lay 6.8-fold (0.83 log units) below the measured number, outside the stated range (above it).
By their numbers in this assay, from the lowest: compounds 2 and 1 (each within the scatter of the next); then compound 3.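

The position on the 4-substituted phenyl ring is not indifferent to every change in this assay: nitro in place of bromo gives a 6.3-fold higher number from compound 2 to compound 3 (0.80 log units; beyond the scatter), and nitro in place of fluoro gives a 5.6-fold higher number from compound 1 to compound 3 (0.75 log units; beyond the scatter). The flat step between the two halogens therefore described only fluoro and bromo, and did not carry over to the 4-nitrophenyl compound, which separates from both halogen compounds while they remain within the scatter of each other. The nitro group differs from bromo in its atoms, its double bond and its hydrogen-bond acceptors, but no measurement shown here says which of these differences, if any, accounts for the higher number.

The compounds shown leave open whether an amine, a nitrile or a methoxy group at this place would stay with the halogens or move with nitro. They also leave open whether the same exchange of bromo for nitro would give a step of similar size on a different core or in other cells.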